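The source may hold more compounds than are shown below. What is called first, only, known or untested is meant among the compounds shown, and "the series" means these compounds.

Of the compounds shown here, three built on a shared core have been measured. In a functional assay on CHO cells for positive allosteric modulation of muscarinic acetylcholine receptor M5 (Homo sapiens), read by calcium flux (a higher number here means a larger maximal response, a lower number a smaller maximal response), compound 1 `CCN(Cc1ccccc1)C(=O)C1CCN(S(=O)(=O)c2ccc(C)s2)CC1` gives 64%. Compound 2 `CCN(Cc1ccccc1C(F)(F)F)C(=O)C1CCN(S(=O)(=O)c2ccc3cn[nH]c3c2)CC1` gives 92% in this assay, and compound 3 `CC(C)N(Cc1ccccc1C(F)(F)F)C(=O)C1CCN(S(=O)(=O)c2ccc3[nH]ncc3c2)CC1` gives 54%. Of these three numbers compound 3 holds the lowest; its value and that of compound 1 sit within the usual scatter of each other, so the two cannot be told apart, whereas the value of compound 2 lies beyond the scatter and clearly higher.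

Compound 4 `O=C(C1CCN(S(=O)(=O)c2ccc3[nH]ncc3c2)CC1)N(Cc1ccccc1C(F)(F)F)CC1CC1` has not yet been measured. It departs from compound 3 in a single place: cyclopropylmethyl in place of isopropyl on an amide-type nitrogen. Going by the values given here, no measured pair in this set shows what such a change does, so the expectation rests on the standing of compound 3 alone. The expected step is small, a number 6 percentage points higher from compound 3 to compound 4 (within the scatter), a shift that would remain inside the scatter of repeated measurements. For compound 4 the estimate in this assay is therefore 60%, with a range running from 40% to 82%.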

Compound 4, largest response reached (reported as percent of maximum), in percent of the reference or control that the assay uses: 102%
For compound 4 the middle estimate is 42 percentage points below the measured one; the whole stated range lies below it.
By their numbers in this assay, from the lowest: compounds 3 and 1 (each within the scatter of the next); then compounds 2 and 4 (each within the scatter of the next).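

Keeping everything else fixed and putting cyclopropylmethyl in place of isopropyl on the amide-type nitrogen gives a number 48 percentage points higher from compound 3 to compound 4 (beyond the scatter) in this assay, a large step. The maximal response is therefore highly sensitive to the group at this position, even though the change goes only from 3 heavy atoms to 4 and neither group has hydrogen-bond donors, acceptors or a net charge. No measurement available here explains why this swap has such an effect.

As far as these compounds go, it remains open whether the step goes with the three-membered ring or simply with the extra carbon, a question that a straight butyl chain or a cyclobutylmethyl group on the same nitrogen could help settle. From the compounds shown here alone, whether the swap has a similar effect when other parts of the shared core are changed also remains unknown.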